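The source may report more compounds than this note shows. Statements on the series, on what has been measured and on what is new or still open speak of the compounds shown alone.

Compound 1, `CC(C)NC(=O)OC[C@H]1OC(n2cnc3c(NC4CCOC4)ncnc32)[C@H](O)[C@@H]1O`, and compound 2, `O[C@@H]1[C@@H](CO/C(S)=N/Cc2ccccc2)OC(n2cnc3c(NC4CCOC4)ncnc32)[C@@H]1O`, share one core and differ only in the group attached to an oxygen on a saturated carbon. In an assay on DDT1 cells (Cricetulus griseus) for binding affinity to adenosine receptor A1 (Homo sapiens), read by radioligand binding (a higher number here means a weaker inhibitor, a lower number a stronger inhibitor), compound 1 gives 78 nM, while compound 2 gives 12 nM. The swap between them, a 6.5-fold lower number from compound 1 to compound 2 (0.81 log units; beyond the scatter), leaves compound 2 with the lowest number of the two measured and makes it the stronger binder of the pair. Compound 3, `C=CCNC(=O)OC[C@H]1OC(n2cnc3c(NC4CCOC4)ncnc32)[C@H](O)[C@@H]1O`, moves in the opposite direction: a group of 6 heavy atoms (4 carbon, 1 nitrogen, 1 oxygen; no ring) in place of a group of 10 heavy atoms (8 carbon, 1 nitrogen, 1 sulfur; one six-membered aromatic ring of carbon only), on an oxygen on a saturated carbon. Among the compounds with values here, the allylcarbamoyl group that enters is a short chain of the same kind as the one compound 1 carries, so that single measured step, read backwards, is the only guide available. Compound 3 is therefore expected to lose most of the gain seen for compound 2, a step of a 5.0-fold higher number from compound 2 to compound 3 (0.70 log units; beyond the scatter) in this assay. The estimate for compound 3 in this assay is 60 nM, with a likely range from 20 nM to 200 nM.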

Compound 3, inhibition constant: 524 nM
Compound 3: the middle estimate sits 8.7-fold (0.94 log units) below what was measured; the measured number lies above the stated range.
By their numbers in this assay, from the lowest: compound 2; then compound 1; then compound 3.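

In this assay, replacing the ring-bearing group of compound 2 with allylcarbamoyl costs far more than the earlier pair suggested (a 44-fold higher number from compound 2 to compound 3 (1.64 log units; beyond the scatter)). The short chains are not interchangeable either: allyl in place of isopropyl on an amide-type nitrogen gives a clear loss (a 6.7-fold higher number from compound 1 to compound 3 (0.83 log units; beyond the scatter)), so even a change at the end of this small group matters, and compound 3 is the weakest of the three. Nothing available explains either difference.

On these data alone, the aromatic ring and the sulfur differ together between compound 2 and compound 3, so their separate contributions remain unknown. As far as these compounds go, it also remains open how an ethyl group, a cyclopentyl group or a longer chain on that amide-type nitrogen would compare with allyl and isopropyl.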